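Compound 3: bromo in place of fluoro

The source may report more compounds than this note shows. Statements on the series, on what has been measured and on what is new or still open speak of the compounds shown alone.

In a functional assay on U-251 cells (Homo sapiens) for antiproliferative activity, read by MTT assay, with a stated time of 48 h (on this read-out lower numbers stand for stronger inhibition and higher numbers for weaker inhibition), compound 1 `COc1ccc(-c2nc3cccc(-c4cc(OC)c(OC)c(OC)c4)c3o2)cc1OC` gives 1300 nM and compound 2 `COc1cc(-c2cccc3nc(-c4cccc(F)c4)oc23)cc(OC)c1OC` gives 2900 nM as the higher of the two numbers, so compound 2 is the weaker inhibitor of this pair. Compound 3 `COc1cc(-c2cccc3nc(-c4cccc(Br)c4)oc23)cc(OC)c1OC` keeps the core of compound 2 and differs from it by one exchange, bromo in place of fluoro on an aromatic carbon on an aromatic carbon, meta to a large group. Within the data shown here, only one measured step exists, a 2.2-fold higher number from compound 1 to compound 2 (0.35 log units; beyond the scatter) and it is modest. Among the measured compounds shown here, that step replaces 3,4-dimethoxyphenyl, so it offers only a rough guide to size, and no measured pair exchanges fluoro for bromo. The expected result in this assay is a small change, a 1.3-fold lower number from compound 2 to compound 3 (0.12 log units; within the scatter) with no firm direction expected beyond the scatter. Compound 3 is estimated at 2200 nM with an expected range from 1000 nM to 4800 nM for repeated measurements.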

Compound 3, half-maximal inhibitory concentration: 6800 nM
The estimate for compound 3 lay 3.1-fold (0.49 log units) below the measured number; the whole stated range lies below it.
By their numbers in this assay, from the lowest: compound 1; then compound 2; then compound 3.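

In this assay this position proves sensitive to a single-atom exchange: bromo in place of fluoro gives a 2.3-fold higher number from compound 2 to compound 3 (0.37 log units; beyond the scatter) and moves the series further from compound 1, so the two halogens cannot be treated as interchangeable here. Taking 3-bromophenyl in place of 3,4-dimethoxyphenyl gives a 5.2-fold higher number from compound 1 to compound 3 (0.72 log units; beyond the scatter) and is the widest step in the set, leaving both compounds with a single halogen above compound 1 by more than the scatter. No measurement at hand accounts for the rise from fluoro to bromo.

With only two halogens at this position, the data do not show whether the numbers follow any trend across the halogens, and chloro would be the obvious point to fill that gap. From the compounds shown here alone, whether a single methoxy, an amine or a carboxylic acid here would come closer to compound 1 also remains open.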